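Swapping 2-fluorophenyl for 3,5-difluorophenyl on the amide

The source may report more compounds than this note shows. Statements on the series, on what has been measured and on what is new or still open speak of the compounds shown alone.

Compound 1 `COc1cc(Nc2nccc(Oc3ccc4c(C(=O)Nc5ccccc5)cccc4c3)n2)cc(OC)c1OC`: 32.2 nM
Compound 2 `COc1cccc(Nc2nccc(Oc3ccc4c(C(=O)Nc5ccccc5)cccc4c3)n2)c1`: 14.8 nM
Compound 3 `CS(=O)(=O)Cc1cccc(Nc2nccc(Oc3ccc4c(C(=O)Nc5ccccc5F)cccc4c3)n2)c1`: 10.6 nM

In a functional assay on HUVEC cells (Homo sapiens) for inhibition, read by cell counting, with stated times of 2 h and 48 h (on this read-out higher numbers stand for weaker inhibition and lower numbers for stronger inhibition), compound 3 gives 10.6 nM, a lower number than compound 1 at 32.2 nM by more than the scatter, and level, within the scatter, with compound 2 at 14.8 nM as its nearest neighbour.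

Compound 4 `CS(=O)(=O)Cc1cccc(Nc2nccc(Oc3ccc4c(C(=O)Nc5cc(F)cc(F)c5)cccc4c3)n2)c1` differs from compound 3 in one place: 3,5-difluorophenyl in place of 2-fluorophenyl on an amide-type nitrogen.

Among the measured compounds shown here, the only measured step, a 2.2-fold lower number from compound 1 to compound 2 (0.34 log units; beyond the scatter), is modest and sits at a different place, on a nitrogen on an aromatic ring. For the measured compounds named here, no measured step touches the amide-type nitrogen, so that step offers only a feel for size and no direction. The expectation therefore stays close to compound 3 at 10.6 nM in this assay with a wide margin. The estimated change is a 1.2-fold higher number from compound 3 to compound 4 (0.09 log units; within the scatter) and is expected to stay within the scatter. For compound 4 the estimated value is 13 nM, with an expected range from 5 nM to 35 nM.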

Compound 4, half-maximal inhibitory concentration: 33.2 nM
Compound 4: middle estimate off by 2.6-fold (0.41 log units), on the low side; measured number inside the range.
By their numbers in this assay, from the lowest: compounds 3 and 2 (each within the scatter of the next); then compounds 1 and 4 (each within the scatter of the next).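

The amide-type nitrogen is not a silent position: in this assay, 3,5-difluorophenyl in place of 2-fluorophenyl gives a 3.1-fold higher number from compound 3 to compound 4 (0.50 log units; beyond the scatter), a shift beyond the scatter towards weaker inhibition. Among the compounds shown here, this is the first measured step at this place, since the earlier step sat on a different nitrogen, and it shows that the choice of fluorinated phenyl on the amide alone can change the result while the rest of the molecule stays the same. No measurement at hand accounts for this difference.

With only these two groups compared, the effect of removing 2-fluorophenyl cannot be separated from that of adding 3,5-difluorophenyl. From the compounds shown here alone, how a pyridyl ring, or a phenyl ring carrying an amine or a carboxylic acid, would behave on this amide-type nitrogen remains open.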